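The source may report more compounds than this note shows. Statements on the series, on what has been measured and on what is new or still open speak of the compounds shown alone.

Compound 1 `Cc1nc([N+](=O)[O-])cn1CC(O)CSC(=S)N1CCN(c2cccc(Cl)c2Cl)CC1` and compound 2 `Cc1nc([N+](=O)[O-])cn1CC(O)CSC(=S)N1CCN(c2ccccc2)CC1` share one core and differ only in the group on the ring nitrogen of the six-membered non-aromatic ring. In a toxicity assay on HeLa cells (Homo sapiens) for cytotoxicity, read by MTT assay, with a stated time of 24 h (a higher number here means a weaker inhibitor, a lower number a stronger inhibitor), compound 1 gives 724000 nM. Compound 2, by contrast, reaches only a limit of this assay, > 5000000 nM. The change between them, phenyl in place of 2,3-dichlorophenyl on an amine nitrogen in a ring, brings an at least 6.9-fold higher number from compound 1 to compound 2 (0.83 log units; beyond the scatter). Compound 2 thus stands at the weak end of the two values shown, and its true number is not known, only that it sits at the limit of > 5000000 nM in this assay, at which 1 of the 2 values shown sits.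

Compound 3 `Cc1nc([N+](=O)[O-])cn1CC(O)CSC(=S)N1CCN(C(=O)OC(C)(C)C)CC1` carries tert-butoxycarbonyl in place of phenyl on an amine nitrogen in a ring. Among the measured compounds shown here, the only measured step, an at least 6.9-fold higher number from compound 1 to compound 2 (0.83 log units; beyond the scatter), concerns a different pair of groups, so it gives no direct guidance for this change. Since compound 2 already lies at a limit, the expected step of a number no higher from compound 2 to compound 3 (the limit leaves the size open) is estimated to be none beyond the scatter. Compound 3 is therefore expected to give about 5000000 nM in this assay, within a range from 1500000 nM to 20000000 nM, most probably again reported as a limit rather than a number.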

Compound 3, half-maximal inhibitory concentration: > 5000000 nM
Compound 3: no number, only a limit; the forecaster's own chance of this, stated with the estimate: 70%; the middle value sits exactly at the limit.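

Replacing 2,3-dichlorophenyl with tert-butoxycarbonyl on this amine nitrogen brings an at least 6.9-fold higher number from compound 1 to compound 3 (0.83 log units; beyond the scatter). A group with no ring therefore moves the result in the same direction as phenyl did, so an aromatic ring in this place is not what separates the two outcomes seen so far. Among the compounds shown, only the 2,3-dichlorophenyl group gives a true number in this assay, and the step from phenyl to tert-butoxycarbonyl cannot be read since both ends of it are limits: the limit of > 5000000 nM in this assay, at which 2 of the 3 values shown sit.

The compounds shown leave open whether the two chlorine atoms are both needed for that number, or whether a phenyl ring with a single chlorine, or with a methyl or methoxy group instead, would also give a number in this assay. They also leave open what a plain hydrogen on this amine nitrogen, or a benzyl group or a simple acetyl group in the same place, would give, and how compound 2 and compound 3 truly compare.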